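The compounds below may be only part of what the source reports. "The series", "measured", "known", "first", "only" and "open" are said of these compounds alone.

Measured in a functional assay on HT529 cells (Homo sapiens) for cytotoxicity; on this read-out higher numbers stand for weaker inhibition and lower numbers for stronger inhibition:
- Compound 1 `CCCCCCCCCCCCCC[C@@H]1N[C@@H](CO)[C@@H]1O`: 0.56 ug/mL
- Compound 2 `CCCCCCCCCCCCCC[C@H]1N[C@@H](CO)[C@H]1O`: 1.65 ug/mL

Compound 2 has the higher number of the pair, and so the weaker inhibition in this assay. Compound 3 `CCCCCCCCCCCCCC[C@@H]1N[C@H](CO)[C@@H]1O` relates to it as follows: the two compounds have the same atoms and bonds and differ only in configuration as drawn: 3 of 3 stereo elements differ (all stereocentres are inverted: mirror images); a stereocentre at a saturated ring carbon is drawn R in compound 2 and S in compound 3; a stereocentre at a saturated ring carbon is drawn S in compound 2 and R in compound 3; a stereocentre at a saturated ring carbon is drawn S in compound 2 and R in compound 3. Among the measured compounds shown here, one measured step bears on this, a 2.9-fold higher number from compound 1 to compound 2 (0.47 log units; beyond the scatter), and it is a modest one, with the fact that compounds 1 and 2 differ only in the configuration as drawn. A step of similar modest size is therefore expected, more likely towards a lower number, although a single step fixes the direction only loosely. The expected change is a 1.7-fold lower number from compound 2 to compound 3 (0.22 log units; within the scatter). For compound 3 the estimate is 1 ug/mL, with an expected range of 0.4 ug/mL to 2.6 ug/mL.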

Compound 3, half-maximal inhibitory concentration: > 2 ug/mL
Compound 3: only a limit was reported; the forecaster's own chance of this, stated with the estimate: 3%; at least 2.0-fold (0.30 log units) between middle value and limit.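

In this assay compound 3 gives > 2 ug/mL, which is a limit of the assay and not a number. Inverting one stereocentre at a saturated ring carbon, with nothing else changed, gives an at least 3.5-fold higher number from compound 1 to compound 3 (0.55 log units; beyond the scatter), so a single configurational change is enough for a step beyond the scatter, where the earlier pair differed at two stereocentres. The full mirror-image change gives an at least 1.2-fold higher number from compound 2 to compound 3 (0.08 log units; that floor lies within the scatter), a floor that leaves the order of that pair unsettled. On these data alone, the true number for compound 3 remains open, as does whether this dependence on configuration would persist with a shorter chain or with a carboxylic acid on the shared core.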